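Two Hydrazide Tails Compared Before a Cyclic Imide Variant

The compounds below may be only part of what the source reports. "The series", "measured", "known", "first", "only" and "open" are said of these compounds alone.

Measured compounds:
- compound 1 `CCOC(=O)C1=C(C)NC(C)=C(C(=O)OCC)C1c1ccc(OCC(=O)NNC(=O)c2ccccc2)cc1`: 29.5%
- compound 2 `CCOC(=O)C1=C(C)NC(C)=C(C(=O)OCC)C1c1ccc(OCC(=O)NNC(=O)CCC(=O)O)cc1`: 43%

Both compounds share one core and differ only in the group attached to the terminal carbonyl carbon of the hydrazide chain. In a functional assay on the whole organism (strain Wistar) for inhibition, with Rattus norvegicus as the target, read by paw edema, with stated times of 30 min and 1 h, at a dose of 20 mg/kg (on this read-out lower numbers stand for less inhibition and higher numbers for more inhibition at the one dose given (going by the name of the read-out)), compound 2 gives 43%, the higher of the two numbers available. Among the measured compounds shown here, its nearest neighbour is compound 1, and the only measured step is a number 13.5 percentage points higher from compound 1 to compound 2 (beyond the scatter).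

Compound 3 `CCOC(=O)C1=C(C)NC(C)=C(C(=O)OCC)C1c1ccc(OCC(=O)NN2C(=O)c3ccccc3C2=O)cc1` has not yet been measured in this assay. The change from compound 2 is a group of 11 heavy atoms (8 carbon, 1 nitrogen, 2 oxygen; one five-membered non-aromatic ring with 1 hetero atom, one six-membered aromatic ring of carbon only) in place of a group of 8 heavy atoms (4 carbon, 1 nitrogen, 3 oxygen; no ring), on an amide-type nitrogen

For the measured compounds named here, no measured step covers this kind of change, in which the open chain bearing the 2-carboxyethyl group is exchanged for a fused ring system closed on the amide-type nitrogen. Going by the values given here, the one step available, from compound 1 to compound 2, shows that the group on this tail can shift the read-out by a modest amount, and compound 3 resembles compound 1 in carrying an aromatic ring in place of the 2-carboxyethyl group. The step to compound 3 is therefore expected to be a number 10 percentage points lower from compound 2 to compound 3 (within the scatter), back toward the lower number of compound 1. The value for compound 3 is estimated at 33%, within a range from 20% to 46%.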

Compound 3, a percentage reported as inhibition, in the whole organism at one dose (the size of the read-out at that dose, not a potency): 42.3%
For compound 3 the middle estimate is 9.3 percentage points below the measured one, within the range that was stated.
By their numbers in this assay, from the lowest: compound 1; then compounds 3 and 2 (each within the scatter of the next).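

In this assay, replacing the open chain on the amide-type nitrogen with the ring-closed group gives a number 0.7 percentage points lower from compound 2 to compound 3 (within the scatter), so at this dose the two tails cannot be told apart, although the entering group has 0 hydrogen-bond donors and the group that leaves has 2. The 2-carboxyethyl group is therefore not needed to reach this level, and an aromatic ring in the tail does not by itself hold the number down, since the tail of compound 1 also carries one and the change to the ring-closed group gives a number 12.8 percentage points higher from compound 1 to compound 3 (beyond the scatter). Nothing measured here offers a reason for either step.

The compounds shown leave open whether the six-membered aromatic ring of the ring-closed group matters, which a five-membered non-aromatic ring without it could test, and whether an open tail ending in an amine, or a longer chain ending in a carboxylic acid, would read differently. With one dose only, they also leave open whether compound 2 and compound 3 would still match at other doses.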